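A few compounds are considered here, and "the series" means these few. Any claim that something is new, unique, unknown or untested is made for them only; others in the source may bear on it.

Measured compounds in an assay on isolated protein for inhibition of Rho-associated protein kinase 1 (Homo sapiens), read by scintillation counting, radiometric assay and 33P incorporation, with a stated time of 40 min, in the presence of a further agent that is not named here; on this read-out higher numbers stand for weaker inhibition and lower numbers for stronger inhibition:

compound 1, `CN(C)c1ccc(C(=O)Nc2cccc(NC(=O)COc3ccc4occc(=O)c4c3)c2)cc1`: compound 1 gives > 10000 nM, which is a limit of the assay and not a number.
compound 2, `Cc1coc2cc(OCC(=O)Nc3cccc(NC(=O)c4ccc(N(C)C)cc4)c3)ccc2c1=O`: compound 2 gives > 10000 nM, likewise a limit and not a number.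
compound 3, `CCc1ccc(C(=O)Nc2cccc(NC(=O)COc3ccc4c(=O)ccoc4c3)c2)cc1`: compound 3 gives 235 nM.

For the measured compounds named here, compound 3 therefore holds the only number in this assay; the other two values sit at the limit of > 10000 nM in this assay, at which 2 of the 3 values shown sit. Going by the values given here, no two of the measured compounds differ in one place only, so no measured step is available to gauge the size of a single change, and the series so far gives no pattern to lean on.

Compound 4, `O=C(COc1ccc2c(=O)ccoc2c1)Nc1cccc(NC(=O)c2ccc(C(=O)O)cc2)c1`, is to be measured in this assay. It differs from compound 3 by carboxy in place of ethyl on an aromatic carbon. The altered carbon is on a six-membered aromatic ring of carbon only, para to a large group, on the (4-ethylphenyl)carbonyl side of compound 3 that becomes (4-carboxyphenyl)carbonyl in compound 4.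

Among the compounds with values here, with no measured step of this kind to go by, the change from compound 3 is expected to cost some inhibition, a step beyond the scatter but well short of the limit, which is what a 3.4-fold higher number from compound 3 to compound 4 (0.53 log units; beyond the scatter) expresses as the expected step. Compound 4 is thus estimated at 800 nM, with a likely range from 200 nM to 4000 nM.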

Compound 4, half-maximal inhibitory concentration: 6890 nM
The estimate for compound 4 lay 8.6-fold (0.94 log units) below the measured number; the measured number lies above the stated range.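

For the compounds shown here, the only measured step falls on the six-membered aromatic ring of carbon only, para to a large group: in this assay, carboxy in place of ethyl gives a 29-fold higher number from compound 3 to compound 4 (1.47 log units; beyond the scatter), so inhibition at this position depends strongly on the group it carries. In this assay, compound 4 still gives a number, 6890 nM. The values of compound 1 and compound 2 remain a limit and not a number: the limit of > 10000 nM in this assay, at which 2 of the 4 values shown sit.

A single step cannot show whether the loss is specific to carboxy or would also follow from other replacements for ethyl at this place, such as an amine, a methyl ester or a longer alkyl chain. Going by these compounds, it also remains open whether the same change would have a step of similar size on a different core, and what lies behind the loss, as nothing here gives a measured cause.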